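This account rests on a few compounds, and the source may have more. Where it says the series, first, only, none or still open, it means among the compounds named here.

Measured so far in a functional assay on Ehrlich cells (Mus musculus) for cytotoxicity, read by trypan blue exclusion, with a stated time of 2 h, tested at 25 ug/mL; on this read-out lower numbers stand for a weaker effect and higher numbers for a stronger effect at the one concentration tested:
- compound 1 `N#CC1=C(NC(=S)Nc2ccccc2)N(c2ccc(S(N)(=O)=O)cc2)C2=C(C(=O)CCC2)C1c1ccc(Cl)cc1Cl`; compound 1 gives 50%
- compound 2 `N#CC1=C(N2C(=O)CCC2=O)N(c2ccc(S(N)(=O)=O)cc2)C2=C(C(=O)CCC2)C1c1ccc(Cl)cc1Cl`; compound 2 gives 50%

Compound 1 stands level with compound 2 at the digits read. Among the measured compounds shown here, the single step between them, no change at the digits printed from compound 1 to compound 2 (within the scatter), exchanges the whole substituent on the double-bonded ring carbon and leaves the read-out where it was, within the scatter.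

Compound 3 `N#CC1=C(NS(=O)(=O)c2ccc([N+](=O)[O-])cc2)N(c2ccc(S(N)(=O)=O)cc2)C2=C(C(=O)CCC2)C1c1ccc(Cl)cc1Cl` keeps the core of compound 1 and alters only the group on the amine nitrogen: a group of 12 heavy atoms (6 carbon, 1 nitrogen, 4 oxygen, 1 sulfur; one six-membered aromatic ring of carbon only) in place of a group of 9 heavy atoms (7 carbon, 1 nitrogen, 1 sulfur; one six-membered aromatic ring of carbon only), on an amine nitrogen. For the measured compounds named here, no measured pair alters this nitrogen alone. Going by the values given here, the one step available, no change at the digits printed from compound 1 to compound 2 (within the scatter), replaces the entire substituent at that position rather than the part on the amine nitrogen and is flat within the scatter, so it bears on the question only loosely. Nothing in the two values points in either direction, and the two measured compounds sit at the same level.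

The step from compound 1 to compound 3 is therefore expected to be no change at the digits printed from compound 1 to compound 3 (within the scatter), none beyond the scatter. For compound 3 the estimate in this assay is 50%, with a range from 35% to 65%.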

Compound 3, a percentage reported as activity, at one concentration (the size of the read-out at that concentration, not a potency): 85%
The estimate for compound 3 lay 35 percentage points below the measured number; measured number above the stated range.
By their numbers in this assay, from the lowest: compounds 1 and 2 (each within the scatter of the next); then compound 3.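

In this assay, the amine nitrogen on the double-bonded ring carbon proves to be a place where the read-out can move: (4-nitrophenyl)sulfonyl, in place of the group of 9 heavy atoms that compound 1 carries there, gives a number 35 percentage points higher from compound 1 to compound 3 (beyond the scatter). The earlier step, no change at the digits printed from compound 1 to compound 2 (within the scatter), had shown only that one exchange of the whole substituent left the read-out flat, so it gave no sign that this position could respond at all, whereas here the core of compound 1 stays the same and the change at this nitrogen alone is enough to shift the result. Nothing available connects this step to any measured property of the entering group.

Still open, as far as these compounds go, is which part of (4-nitrophenyl)sulfonyl carries the step, a question that a plain phenylsulfonyl, a (4-aminophenyl)sulfonyl or a methylsulfonyl group on the same nitrogen would help to separate. With a single concentration in a single assay, the compounds shown also leave open whether the step reflects a difference in potency, and whether it would hold on cells other than Ehrlich cells.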